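The source may report more compounds than this note shows. Statements on the series, on what has been measured and on what is new or still open speak of the compounds shown alone.

Three members of the series have been run in an ADME assay on NCM460 cells (Homo sapiens) for cytotoxicity, read by MTT assay, with a stated time of 72 h; on this read-out higher numbers stand for weaker inhibition and lower numbers for stronger inhibition. Compound 1 `Cc1ccc(N2C(=O)C/C(=C\c3cccc(C(=O)Nc4cccc(F)c4)c3)C2=O)cc1` is the starting point of the step followed here, and in this assay compound 1 returns only a limit, > 100000 nM. Compound 2 `CCc1cccc(NC(=O)c2cccc(/C=C3\CC(=O)N(Cc4ccccc4)C3=O)c2)c1` likewise gives a limit in this assay, > 100000 nM. Compound 3 `COc1cc(NC(=O)c2cccc(/C=C3\CC(=O)N(c4ccccc4)C3=O)c2)cc(OC)c1OC` also stops at a limit in this assay, > 100000 nM. Among the compounds with values here, no numerical value is thus available for any of the three and no step between measured compounds can be sized; all that is known is the limit of > 100000 nM in this assay, at which 3 of the 3 values shown sit, so compound 1 stands nowhere distinguishable from compound 2 or compound 3 on the half-maximal inhibitory concentration.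

The step under consideration leads from compound 1 to compound 4 `O=C(Nc1cccc(F)c1)c1cccc(/C=C2\CC(=O)N(c3ccccc3)C2=O)c1`. The change is hydrogen in place of methyl on an aromatic carbon, para to a large group, or, cut one bond further out, 4-methylphenyl to phenyl. The amide, the exocyclic double bond and the shared core are untouched. Within the data shown here, with every measured member sitting at the same limit, no step in this assay beyond the usual scatter is expected from so small a change, and a further limit is the likeliest outcome.

Compound 4 is accordingly expected to give 150000 nM, within 60000 nM to 500000 nM. The expected step is a step that the limit leaves unreadable from compound 1 to compound 4, no movement beyond the scatter.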

Compound 4, half-maximal inhibitory concentration: > 100000 nM
Compound 4: only a limit was reported; the forecaster's own chance of this, stated with the estimate: 85%; the middle value is on the limit's open side.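

In this assay compound 1 and compound 4 both return only a limit, so the step between them, hydrogen in place of methyl on an aromatic carbon, cannot be read. The compounds shown leave open whether any change to the series yields a numerical half-maximal inhibitory concentration in this assay at all: the limit of > 100000 nM in this assay, at which 4 of the 4 values shown sit.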